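Hydroxy Replacing Iodo on the Methoxyphenyl Ring

This account rests on a few compounds, and the source may have more. Where it says the series, first, only, none or still open, it means among the compounds named here.

Measured so far:
compound 1 `COc1ccc(-c2nc3cc(F)ccc3s2)cc1C` gives 48 nM
compound 2 `COc1ccc(-c2nc3cc(F)ccc3s2)cc1I` gives 820 nM

Both compounds were tested in a functional assay on MCF7 cells (Homo sapiens) for antiproliferative activity; on this read-out higher numbers stand for weaker inhibition of growth and lower numbers for stronger inhibition of growth. Going by the values given here, compound 2 has the highest number of the two; its only neighbour is compound 1, which differs by a single group, and the step of a 17-fold higher number from compound 1 to compound 2 (1.23 log units; beyond the scatter) is large.

Compound 3 `COc1ccc(-c2nc3cc(F)ccc3s2)cc1O` is not yet measured. It differs from compound 2 by hydroxy in place of iodo on an aromatic carbon, on the same aromatic carbon that was changed between compound 1 and compound 2. Among the compounds with values here, the one measured step that bears on this position shows that a single group here can move the number well beyond the scatter. No direct comparison of hydroxy with either methyl or iodo exists, so the direction is uncertain. A moderate return toward a lower number is expected for compound 3, with the estimated step of a 4.1-fold lower number from compound 2 to compound 3 (0.61 log units; beyond the scatter). Compound 3 is therefore estimated at 200 nM, within a range from 40 nM to 1000 nM.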

Compound 3, concentration for 50% growth inhibition: 500 nM
Compound 3: middle estimate off by 2.5-fold (0.40 log units), on the low side, and the stated range covers the measured number.
By their numbers in this assay, from the lowest: compound 1; then compounds 3 and 2 (each within the scatter of the next).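

In this assay, hydroxy in place of iodo gives a 1.6-fold lower number from compound 2 to compound 3 (0.21 log units; within the scatter), so the two groups cannot be told apart on this read-out, even though hydroxy carries a hydrogen-bond donor and acceptor and iodo carries neither. Methyl now stands apart from both, since hydroxy in its place gives a 10-fold higher number from compound 1 to compound 3 (1.02 log units; beyond the scatter) and the earlier step to iodo was also large; among these three compounds, only methyl gives the low number. Nothing measured for these compounds accounts for this difference.

From the compounds shown here alone, whether methyl is alone in this remains open, as an ethyl group, a chlorine or fluorine atom, or an amine on the same aromatic carbon would test how narrow the preference is. A carboxylic acid there would show whether any group can push the number well above those of iodo and hydroxy.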